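Removing a Methyl from Compound 2: Expected Effect on Potency

A few compounds are considered here, and "the series" means these few. Any claim that something is new, unique, unknown or untested is made for them only; others in the source may bear on it.

Compound 1: `Cc1cccc(NC(=O)c2nc(C)ccc2O)n1` — 7 nM
Compound 2: `CCOc1cccnc1Nc1cccc(C)n1` — 40 nM

Of the compounds shown here, two have been measured in an assay on Ltk cells with metabotropic glutamate receptor 5 (Homo sapiens) as the target, read by fluorescence and calcium flux; a higher number here means a weaker inhibitor, a lower number a stronger inhibitor. Compound 1 gives 7 nM, and compound 2 gives 40 nM, the higher of the two numbers; the gap between them lies beyond the usual scatter. For the measured compounds named here, the two compounds share no simple single-point step, so their values are stated side by side without further comparison.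

Compound 3, `CCOc1cccnc1Nc1ccccn1`, differs from compound 2 in one place: hydrogen in place of methyl on an aromatic carbon. The change sits on an aromatic carbon of a six-membered aromatic ring with one nitrogen, next to the ring nitrogen and meta to a large group. Going by the values given here, no measured pair shows what such a loss of a methyl does here, so the expectation rests on compound 2 alone. The step from compound 2 to compound 3 is expected to be a modest rise in the number, a 2.5-fold higher number from compound 2 to compound 3 (0.40 log units; beyond the scatter), in the direction of a weaker inhibitor, near the edge of the scatter. Compound 3 is accordingly estimated at 100 nM, within a range from 30 nM to 400 nM.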

Compound 3, half-maximal inhibitory concentration: 138 nM
For compound 3 the middle estimate is 1.4-fold (0.14 log units) below the measured one; the measured number falls inside the stated range.
By their numbers in this assay, from the lowest: compound 1; then compound 2; then compound 3.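

Taking the methyl away gives a 3.5-fold higher number from compound 2 to compound 3 (0.54 log units; beyond the scatter) in this assay and provides the first measured single-place change in this set. On this aromatic carbon, next to the ring nitrogen and meta to a large group, the methyl therefore makes a difference: the step is modest but lies beyond the scatter, and compound 2, which keeps the methyl, is the stronger inhibitor. Nothing measured here accounts for the size of this step.

As far as these compounds go, the two compounds with this core show only methyl and hydrogen at this carbon, so it remains open whether an ethyl, a chlorine or a methoxy there would give a lower or a higher number. From the compounds shown here alone, it also remains open whether the same change on the core of compound 1 would give a step of similar size.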